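A smaller fluorinated aryl group on the sulfonyl sulfur

The compounds below may be only part of what the source reports. "The series", "measured", "known", "first", "only" and "open" are said of these compounds alone.

Three compounds sharing one core differ only in the aryl group on the sulfonyl sulfur. In an assay for inhibition of Nicotinamide phosphoribosyltransferase (Homo sapiens), read by mass spectrometry, with stated times of 15 min and 30 min (a lower number here means a stronger inhibitor, a higher number a weaker inhibitor), compound 1 `Cc1cccc(S(=O)(=O)c2ccc(CNC(=O)c3cc4cnccc4[nH]3)cc2)c1` gives 8 nM, and compound 2 `O=C(NCc1ccc(S(=O)(=O)c2ccc(F)c(F)c2)cc1)c1cc2cnccc2[nH]1` gives 10 nM; the step of a 1.3-fold higher number from compound 1 to compound 2 (0.10 log units; within the scatter) separates them. Compound 3 `O=C(NCc1ccc(S(=O)(=O)c2ccccc2C(F)(F)F)cc1)c1cc2cnccc2[nH]1` gives 24 nM in this assay, the highest number of the three: the steps are a 3.0-fold higher number from compound 1 to compound 3 (0.48 log units; beyond the scatter) and a 2.4-fold higher number from compound 2 to compound 3 (0.38 log units; beyond the scatter).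

Compound 4 `O=C(NCc1ccc(S(=O)(=O)c2cccc(F)c2)cc1)c1cc2cnccc2[nH]1` is the next compound. Compared with compound 3 the change is 3-fluorophenyl in place of 2-(trifluoromethyl)phenyl on a sulfonyl sulfur.

The two steps that bear on this are those into compound 3, a 3.0-fold higher number from compound 1 to compound 3 (0.48 log units; beyond the scatter) and a 2.4-fold higher number from compound 2 to compound 3 (0.38 log units; beyond the scatter), both of which put the 2-(trifluoromethyl)phenyl compound at a modestly higher number than a compound carrying a 3-methylphenyl or a 3,4-difluorophenyl. For the measured compounds named here, a 3-fluorophenyl resembles those two groups more than it resembles the 2-(trifluoromethyl)phenyl, so a modest drop in the number is expected in this assay, though no measured compound carries a 3-fluorophenyl, so the size is uncertain. Compound 4 is therefore expected to show a step of a 2.4-fold lower number from compound 3 to compound 4 (0.38 log units; beyond the scatter). Compound 4 is estimated at 10 nM in this assay, within a range from 5 nM to 20 nM.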

Compound 4, half-maximal inhibitory concentration: 5 nM
Compound 4: the middle estimate sits 2.0-fold (0.30 log units) above what was measured; the measured number falls inside the stated range.
By their numbers in this assay, from the lowest: compounds 4, 1 and 2 (each within the scatter of the next); then compound 3.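

In this assay, 3-fluorophenyl in place of 2-(trifluoromethyl)phenyl on the sulfonyl sulfur gives a 4.8-fold lower number from compound 3 to compound 4 (0.68 log units; beyond the scatter), so a third aryl group now stands clear of compound 3. Hydrogen in place of fluoro gives a 2.0-fold lower number from compound 2 to compound 4 (0.30 log units; within the scatter) and fluoro in place of methyl gives a 1.6-fold lower number from compound 1 to compound 4 (0.20 log units; within the scatter); both lie within the scatter, so compound 1, compound 2 and compound 4 cannot be told apart here. Nothing available explains why the 2-(trifluoromethyl)phenyl compound stands apart from the other three.

It remains open whether the higher number of compound 3 belongs to the trifluoromethyl group itself or to its place on the ring, as no other compound shown carries that group. Also open, as far as these compounds go, is how a cyclohexyl group, or an aryl group carrying an amine or a carboxylic acid, would read on the sulfonyl sulfur.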